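Adding a methylsulfanyl group to the benzyl ring of compound 2

The source may hold more compounds than are shown below. What is called first, only, known or untested is meant among the compounds shown, and "the series" means these compounds.

Going by the values given here, compound 2 `C[Se]c1nc(NCc2ccccc2)c2ccccc2n1` gives the lowest of the two numbers so far in a functional assay on MCF7 cells (Homo sapiens) for cytotoxicity, read by MTT assay, with a stated time of 72 h; on this read-out lower numbers stand for stronger inhibition of growth and higher numbers for weaker inhibition of growth: compound 2 gives 15800 nM, whereas compound 1 `COc1ccc(CNc2nc([Se]C)nc3ccccc23)cc1` gives 42200 nM. Among the compounds with values here, the one measured step, a 2.7-fold lower number from compound 1 to compound 2 (0.43 log units; beyond the scatter), shows that removing a methoxy group from the benzyl ring helped. Compound 3 `CSc1ccc(CNc2nc([Se]C)nc3ccccc23)cc1` goes the other way: it carries methylsulfanyl in place of hydrogen on an aromatic carbon, on the same carbon that held the methoxy group in compound 1, para to a large group. Within the data shown here, the methoxy step is the only guide, and it suggests that placing a group at this spot pushes the number up. A methylsulfanyl group is not a methoxy group, so the size is uncertain, but a modest rise is expected, with a 1.9-fold higher number from compound 2 to compound 3 (0.28 log units; within the scatter). Compound 3 is therefore estimated at 30000 nM, with a likely range from 12000 nM to 80000 nM.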

Compound 3, concentration for 50% growth inhibition: 54100 nM
For compound 3 the middle estimate is 1.8-fold (0.26 log units) below the measured one; measured number inside the range.
By their numbers in this assay, from the lowest: compound 2; then compounds 1 and 3 (each within the scatter of the next).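

In this assay, going by these compounds alone, methylsulfanyl in place of hydrogen on the aromatic carbon gives a 3.4-fold higher number from compound 2 to compound 3 (0.53 log units; beyond the scatter), so methoxy is no longer the only group seen to weaken growth inhibition at this position. Exchanging one group for the other gives a 1.3-fold higher number from compound 1 to compound 3 (0.11 log units; within the scatter), which means this read-out cannot separate methylsulfanyl from methoxy here, and both compounds carrying a group at this carbon stand apart from the unsubstituted compound 2. Nothing available explains this shared result.

Going by these compounds, it remains open whether every group at this carbon raises the number, since a fluorine atom, an amine or a carboxylic acid could behave differently. On these data alone, the effect of placing methoxy or methylsulfanyl elsewhere on the same aromatic ring also remains unknown.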